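The compounds below may be only part of what the source reports. "The series", "measured", "known", "first", "only" and "open" are said of these compounds alone.

In an ADME assay for permeability, using PAMPA, at pH 7.4 (on this read-out higher numbers stand for higher permeability and lower numbers for lower permeability), compound 2 (`CCc1ccc(NC(=O)Nc2cc(C)nc3ccccc23)cc1`) gives 535 10^-6 cm/s. Compound 3 (`COc1ccc(NC(=O)Nc2cc(C)nc3ccccc23)cc1Cl`) gives 336 10^-6 cm/s, which lies within the scatter of that number. Compound 1 (`Cc1cc(NC(=O)Nc2ccc(Cl)c(Cl)c2)c2ccccc2n1`) gives 197 10^-6 cm/s, a lower number that lies beyond the scatter of the value for compound 2. The unmeasured compound 4 (`COC(=O)c1ccc(NC(=O)Nc2cc(C)nc3ccccc23)cc1`) has methoxycarbonyl in place of ethyl on an aromatic carbon, para to a large group: methoxycarbonyl in place of ethyl on an aromatic carbon. Among the compounds with values here, no measured step replaces ethyl. Within the data shown here, the only step between measured compounds is a different exchange, methoxy in place of chloro on an aromatic carbon, and it gave a 1.7-fold higher number from compound 1 to compound 3 (0.23 log units; within the scatter). Among the measured compounds shown here, with that step from compound 1 as the only guide, no step beyond the scatter is expected in this assay. A slight lean towards a lower number is a judgement from the structural change alone, and the data do not test it. The estimate means a 1.8-fold lower number from compound 2 to compound 4 (0.25 log units; within the scatter), an expected step that stays within the scatter. For compound 4 the estimated value is 300 10^-6 cm/s, with an expected range from 130 10^-6 cm/s to 600 10^-6 cm/s.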

Compound 4, apparent permeability: 448 10^-6 cm/s
Compound 4: the middle estimate sits 1.5-fold (0.17 log units) below what was measured; low and high end bracket the measured number.
By their numbers in this assay, from the lowest: compounds 1, 3, 4 and 2 (each within the scatter of the next, the first and the last beyond it).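

In this assay, methoxycarbonyl in place of ethyl on an aromatic carbon, para to a large group, gave a 1.2-fold lower number from compound 2 to compound 4 (0.08 log units; within the scatter) as the only step shown that replaces ethyl. It shows that at this place a group carrying hydrogen-bond acceptors and a double bond outside the aromatic rings, neither of which ethyl has, can take the place of a plain alkyl group without a step beyond the scatter. The compounds shown offer no evidence on what lies behind this result.

As far as these compounds go, whether an amine, a carboxylic acid or a longer chain at the same place would also stay within the scatter of ethyl remains open. Also open, from the compounds shown here alone, is whether methoxycarbonyl would give a similar step on an aromatic carbon elsewhere on this ring.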